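This account rests on a few compounds, and the source may have more. Where it says the series, first, only, none or still open, it means among the compounds named here.

Values measured in a functional assay on a cell-free system (Platelet, plasma, Homo sapiens) for inhibition (a lower number here means a stronger inhibitor, a higher number a weaker inhibitor), are as follows:
- compound 1 `O=C(NC[C@H](NS(=O)(=O)c1cccs1)C(=O)O)c1ccc(N2CCC[C@H](NC3=NCCCN3)C2)cc1` gives 99 nM
- compound 2 `O=C(NC[C@H](NS(=O)(=O)c1ccccc1)C(=O)O)c1ccc(N2CCC[C@H](NC3=NCCCN3)C2)cc1F` gives 290 nM
- compound 3 `O=C(NC[C@H](NS(=O)(=O)c1ccc(O)cc1)C(=O)O)c1ccc(N2CCC(NC3=NCCCN3)CC2)c(F)c1` gives 230 nM

Compound 2 (290 nM) lies within the scatter of compound 3 (230 nM). Set against compound 1 (99 nM), compound 2 is the weaker inhibitor, by a gap beyond the scatter.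

Compound 4 `O=C(NC[C@H](NS(=O)(=O)c1ccccc1)C(=O)O)c1ccc(N2CCC[C@H](NC3=NCCCN3)C2)cc1` departs from compound 2 in one place (hydrogen in place of fluoro on an aromatic carbon), with hydrogen in place of fluoro on an aromatic carbon. Going by the values given here, no pair of measured compounds shows this change alone, so the data offer no direct guide to its size or direction in this assay. The change is therefore expected to be small, and the estimated step (a 1.5-fold lower number from compound 2 to compound 4 (0.16 log units; within the scatter)) is expected to stay within the scatter, with no firm direction. For compound 4 the estimated value is 200 nM in this assay, with an expected range from 80 nM to 500 nM as the measurement awaited.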

Compound 4, half-maximal inhibitory concentration in the Platelet assay: 83 nM
The estimate for compound 4 lay 2.4-fold (0.38 log units) above the measured number; the measured number falls inside the stated range.
By their numbers in the Platelet assay, from the lowest: compounds 4 and 1 (each within the scatter of the next); then compounds 3 and 2 (each within the scatter of the next).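

Going by these compounds alone, in the Platelet assay compound 2 gives 290 nM and compound 4 gives 83 nM; hydrogen in place of fluoro on an aromatic carbon, ortho to a large group and meta to a large group, gives a 3.5-fold lower number from compound 2 to compound 4 (0.54 log units; beyond the scatter), so the exchange of this single atom registers beyond the scatter, which no earlier pair of compounds could show. The loss of the fluoro group also makes the sulfonyl substituent comparable: phenyl in place of thiophen-2-yl on a sulfonyl sulfur gives a 1.2-fold lower number from compound 1 to compound 4 (0.08 log units; within the scatter), a step within the scatter. In a physicochemical assay for solubility (a lower number here means a less soluble compound, a higher number a more soluble compound), compound 2 gives 2800 ug/mL and compound 4 gives 3500 ug/mL; the fluoro change gives a 1.3-fold higher number from compound 2 to compound 4 (0.10 log units; within the scatter), also within the scatter, and nothing at hand accounts for either fluoro step.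

The compounds shown leave open whether the step in potency belongs to fluoro alone or to any group at this place, as a chloro or a methoxy group on the same aromatic carbon stands among none of them. Also open, going by these compounds, is whether fluoro has the same weight with thiophen-2-yl on the sulfonyl sulfur.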